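Trimming the chain terminus of compound 1 in OVCAR-8 cells

The source may report more compounds than this note shows. Statements on the series, on what has been measured and on what is new or still open speak of the compounds shown alone.

Measured so far:
compound 1 `Cn1ncc(Cl)c1-c1cc(C(=O)N[C@@H]2CN[C@H](CCN3CCC(O)CC3)C[C@H]2c2ccc(Cl)c(Cl)c2)oc1Cl` — 15900 nM
compound 2 `Cn1ncc(Cl)c1-c1cc(C(=O)N[C@@H]2CN[C@H](CCO)C[C@H]2c2ccc(F)c(F)c2)oc1Cl` — 460 nM
compound 3 `CC(=O)NCC[C@@H]1C[C@@H](c2ccc(F)c(F)c2)[C@H](NC(=O)c2cc(-c3c(Cl)cnn3C)c(Cl)o2)CN1` — 880 nM

Of the compounds shown here, three sharing one amide-linked core have been tested in a functional assay on OVCAR-8 cells (Homo sapiens) for antiproliferative activity; a higher number here means a weaker inhibitor, a lower number a stronger inhibitor. Compound 1 gives 15900 nM, the highest of the three numbers; compound 3 gives 880 nM and compound 2 gives 460 nM, and both gaps from compound 1 are beyond the scatter. Compound 2 and compound 3 differ only at the chain terminus, and a 1.9-fold higher number from compound 2 to compound 3 (0.28 log units; within the scatter) stays within the scatter.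

Compound 4 `CCC[C@@H]1C[C@@H](c2ccc(Cl)c(Cl)c2)[C@H](NC(=O)c2cc(-c3c(Cl)cnn3C)c(Cl)o2)CN1` is the next candidate. It is derived from compound 1 by methyl in place of 4-hydroxypiperidin-1-yl on a saturated chain carbon, two bonds along the chain from a saturated ring carbon. Going by the values given here, the only measured step at this place, a 1.9-fold higher number from compound 2 to compound 3 (0.28 log units; within the scatter), put acetamido in place of hydroxy and moved the number little; no measured step removes the ring that leaves here, and compound 1 also differs from compound 2 and compound 3 in the halogens on the phenyl ring, so the gap of compound 1 to the others cannot be assigned to the chain alone. Compound 4 is therefore expected to land between these cases, with a 4.0-fold lower number from compound 1 to compound 4 (0.60 log units; beyond the scatter) as the estimated step, giving compound 4 an expected value of 4000 nM within a range of 800 nM to 20000 nM.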

Compound 4, half-maximal inhibitory concentration: 1620 nM
The estimate for compound 4 lay 2.5-fold (0.39 log units) above the measured number; low and high end bracket the measured number.
By their numbers in this assay, from the lowest: compounds 2, 3 and 4 (each within the scatter of the next, the first and the last beyond it); then compound 1.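

In this assay, with the chlorinated phenyl ring and the rest of the core unchanged, methyl in place of 4-hydroxypiperidin-1-yl gives a 9.8-fold lower number from compound 1 to compound 4 (0.99 log units; beyond the scatter). This shows that the number responds to a change at this place, which the earlier step at the chain terminus, a 1.9-fold higher number from compound 2 to compound 3 (0.28 log units; within the scatter), did not show, and that the 4-hydroxypiperidin-1-yl ring is not needed for antiproliferative activity in this series. No measurement here offers an explanation for this step.

From the compounds shown here alone, it remains open whether the step follows the loss of the whole ring, its hydroxy group or its nitrogen, which a plain piperidin-1-yl, a dimethylamino group or a longer alkyl chain at this place could help to separate. The contribution of the phenyl halogens also stays open, since no pair shown differs only in chlorine against fluorine there.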